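Swapping a Methoxyphenyl Group for a Dimethoxyphenyl Group

A few compounds are considered here, and "the series" means these few. Any claim that something is new, unique, unknown or untested is made for them only; others in the source may bear on it.

In a functional assay on HL-60 cells (Homo sapiens) for antiproliferative activity, read by MTT assay, with a stated time of 72 h (on this read-out higher numbers stand for weaker inhibition and lower numbers for stronger inhibition), compound 2 `COc1ccc(-c2c(C(=O)c3cc(OC)c(OC)c(OC)c3)sc3ccccc23)cc1` gives 1600 nM and compound 1 `COc1cc(C(=O)c2sc3ccccc3c2-c2ccc(F)cc2)cc(OC)c1OC` gives 3200 nM, two values within the usual scatter of each other. Compound 3 `COc1ccc(OC)c(-c2c(C(=O)c3cc(OC)c(OC)c(OC)c3)sc3ccccc23)c1` carries 2,5-dimethoxyphenyl in place of 4-methoxyphenyl on an aromatic carbon. Within the data shown here, only one measured step bears on this change: a 2.0-fold lower number from compound 1 to compound 2 (0.30 log units; within the scatter), with methoxy in place of fluoro, stayed within the scatter. Among the measured compounds shown here, no measured compound carries two methoxy groups on this phenyl, so the guide is thin. The expected change in this assay is a 1.3-fold higher number from compound 2 to compound 3 (0.10 log units; within the scatter), nothing beyond the scatter. For compound 3 the estimate is 2000 nM, with an expected range of 600 nM to 7000 nM.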

Compound 3, half-maximal inhibitory concentration: > 10000 nM
Compound 3 was reported as a limit; the forecaster's own chance of this, stated with the estimate: 8%; middle value at least 5.0-fold (0.69 log units) away from the limit.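

In this assay compound 3 is reported only as a limit, not a number: the limit of > 10000 nM in this assay, at which 1 of the 3 values shown sits.

Replacing fluoro with methoxy on this phenyl stayed within the scatter, but 2,5-dimethoxyphenyl gives an at least 6.2-fold higher number from compound 2 to compound 3 (0.79 log units; beyond the scatter) and an at least 3.1-fold higher number from compound 1 to compound 3 (0.49 log units; beyond the scatter). This position therefore does respond to the group it carries, and this change weakens inhibition beyond the scatter.

It remains open which of the two methoxy groups in 2,5-dimethoxyphenyl accounts for the loss. Also open, as far as these compounds go, is how a phenyl carrying a hydroxyl or an amine at this position would behave.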